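A few compounds are considered here, and "the series" means these few. Any claim that something is new, unique, unknown or untested is made for them only; others in the source may bear on it.

In an assay on HEK293 cells for inhibition of sodium channel protein type 3 subunit alpha (Homo sapiens), read by electrophysiology, with a stated time of 3.5 min (on this read-out lower numbers stand for stronger inhibition and higher numbers for weaker inhibition), compound 1 `CNC(=O)[C@@H]1CC[C@H](c2ccc(OCc3ccccc3F)cc2)N1` gives > 63000 nM, which is a limit of the assay rather than a number. Compound 2 `NC(=O)[C@@H]1CC[C@H](c2cccc(OCc3ccccc3)c2)N1` gives > 100000 nM, again only a limit. Compound 3 `N#Cc1ccccc1COc1ccc([C@H]2CC[C@@H](C(N)=O)N2)cc1` gives > 63000 nM, also a limit, so compound 3 stands among three compounds for which no measurable inhibition has been found. Compound 4 `N#Cc1ccc(COc2ccc([C@H]3CC[C@@H](C(N)=O)N3)cc2)cc1` has not been measured and differs from compound 3 in one place: 4-cyanophenyl in place of 2-cyanophenyl on a saturated chain carbon bound to an oxygen on an aromatic ring. Within the data shown here, no step between two measured compounds is available to calibrate this change. Because the shown values sit at the limit of > 100000 nM in this assay, at which 1 of the 3 values shown sits, and (the limit of > 63000 nM in this assay, at which 2 of the 3 values shown sit), no movement beyond the usual scatter is expected. Compound 4 is therefore expected to give 80000 nM, within 30000 nM to 200000 nM. That estimate means the expected step that the limit leaves unreadable from compound 3 to compound 4.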

Compound 4, half-maximal inhibitory concentration: > 63000 nM
Compound 4 gave a limit, no number; the forecaster's own chance of this, stated with the estimate: 85%; the middle value lies beyond the limit too.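

Among these compounds, compound 3 and compound 4 each gave only a limit of the assay, not a number, and no step between them can be read. The compounds shown leave open whether 4-cyanophenyl in place of 2-cyanophenyl changes inhibition at all.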